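The source may report more compounds than this note shows. Statements on the series, on what has been measured and on what is new or still open speak of the compounds shown alone.

Measured compounds in an assay on isolated protein for inhibition of Apoptosis regulator Bcl-2 (Homo sapiens), read by fluorescence polarization, with stated times of 5 min and 10 min; on this read-out higher numbers stand for weaker inhibition and lower numbers for stronger inhibition:
compound 1 `COC(=O)CCNC(=O)[C@@H]1CC=C(CCC=C(C)C)C[C@H]1c1ccccc1` — > 23000 nM
compound 2 `CC(C)=CCCC1=CC[C@H](C(=O)Nc2ccc(O)cc2)[C@@H](c2ccccc2)C1` — > 23000 nM

Working notes on the series. The value for compound 1 in this assay is a limit of the assay rather than a number, > 23000 nM. The value for compound 2 in this assay is likewise a limit and not a number, > 23000 nM. Where compound 2 stands is therefore only this: both values shown sit at the limit, as noted in the limit of > 23000 nM in this assay, at which 2 of the 2 values shown sit. Within the data shown here, no step between measured compounds is available.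

Compound 3 `COC(=O)CCNC(=O)[C@H]1CC=C(CCC=C(C)C)C[C@@H]1c1ccccc1` is not yet measured. It is related to compound 2 by 2-(methoxycarbonyl)ethyl in place of 4-hydroxyphenyl on an amide-type nitrogen, whose other neighbours are a carbonyl carbon. With both measured compounds at the limit, no direction of change beyond the scatter can be read, and for compound 3 the step that the limit leaves unreadable from compound 2 to compound 3 is expected to be none that the assay resolves. Compound 3 is estimated at 35000 nM, in the range 15000 nM to 120000 nM, most likely again reported only as a limit.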

Compound 3, inhibition constant: 3100 nM
Beside the measured number, compound 3's estimate is 11-fold (1.05 log units) above it; the whole stated range lies above it.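

In this assay, the change at the amide-type nitrogen, 2-(methoxycarbonyl)ethyl in place of 4-hydroxyphenyl, now gives a readable step: an at least 7.4-fold lower number from compound 2 to compound 3 (0.87 log units; beyond the scatter). The mirror-image pair gives an at least 7.4-fold lower number from compound 1 to compound 3 (0.87 log units; beyond the scatter), so the configuration as drawn alone separates a measured number from a limit, with atoms and bonds unchanged: the fact that compounds 1 and 3 differ only in the configuration as drawn. Both steps are open-ended, as each starts from a compound reported only as a limit: the limit of > 23000 nM in this assay, at which 2 of the 3 values shown sit.

As far as these compounds go, the true size of either step remains unknown, and so does how much of the 2-(methoxycarbonyl)ethyl group is needed. A carboxylic acid in place of the methyl ester, an amine at the end of the chain, or a longer chain on the amide-type nitrogen could each show whether the number moves further in this assay.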